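Exchanging the Aryl Ring on the Hydrazone

The compounds below may be only part of what the source reports. "The series", "measured", "known", "first", "only" and "open" are said of these compounds alone.

Compound 2 `CCCSc1nc(N/N=C/c2ccc(C)cc2)c2nnn(Cc3ccccc3)c2n1` carries a 4-methylphenyl group on the hydrazone carbon. In a functional assay on MGC-803 cells (Homo sapiens) for antiproliferative activity, read by MTT assay, with a stated time of 72 h (a higher number here means a weaker inhibitor, a lower number a stronger inhibitor), compound 2 reaches only the limit of the assay, > 64000 nM, so no number is known for it. In this assay compound 3 `CCCSc1nc(N/N=C/c2ccc([N+](=O)[O-])cc2)c2nnn(Cc3ccccc3)c2n1` gives 10100 nM, and the step of an at least 6.3-fold lower number from compound 2 to compound 3 (0.80 log units; beyond the scatter) shows that a change on this ring can move the number beyond the scatter. Compound 1 `CCCSc1nc(N/N=C(\C)c2ccccc2O)c2nnn(Cc3ccccc3Cl)c2n1`, with a different benzyl group and aryl ring, gives 35000 nM. Compound 4 `CCCSc1nc(N/N=C/c2cccc(Cl)c2)c2nnn(Cc3ccccc3)c2n1` differs from compound 2 by 3-chlorophenyl in place of 4-methylphenyl on a carbon with a double bond to nitrogen. Within the data shown here, only the step from compound 2 to compound 3 bears on this change. A move in the same direction, toward a lower number, is expected, an at least 2.5-fold lower number from compound 2 to compound 4 (0.40 log units; beyond the scatter). The expected value for compound 4 is therefore 25000 nM, with a range from 8000 nM to 64000 nM.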

Compound 4, half-maximal inhibitory concentration: > 64000 nM
Compound 4 ended at the assay's limit; the forecaster's own chance of this, stated with the estimate: 30%; middle value at least 2.5-fold (0.40 log units) from the limit.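

In this assay, swapping the 4-nitrophenyl ring for a 3-chlorophenyl ring gives an at least 6.3-fold higher number from compound 3 to compound 4 (0.80 log units; beyond the scatter). So the lower number of compound 3 does not carry over to every new aryl ring at this position, and among these two rings only 4-nitrophenyl gives a readable value. The step between compound 2 and compound 4 cannot be read because both stop at a limit: the limit of > 64000 nM in this assay, at which 2 of the 4 values shown sit.

Still open, going by these compounds, is whether the nitro group itself matters or whether other groups on this ring could also lower the number. A 4-aminophenyl or 4-chlorophenyl ring would test this.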